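Bromo in Place of Hydrogen: What Compound 4 Should Give

A few compounds are considered here, and "the series" means these few. Any claim that something is new, unique, unknown or untested is made for them only; others in the source may bear on it.

Measured so far:
compound 1 `COc1cc2c(Oc3ccc(NC(=O)c4nn(-c5ccccc5)c(=O)c5ccccc45)cc3F)ccnc2cc1OCCCN1CCCC1` — 480 nM
compound 2 `COc1cc2c(Oc3ccc(NC(=O)c4nn(-c5cccc(F)c5)c(=O)c5ccccc45)cc3F)ccnc2cc1OCCCN1CCCC1` — 190 nM
compound 3 `COc1cc2c(Oc3ccc(NC(=O)c4nn(-c5ccccc5F)c(=O)c5ccccc45)cc3F)ccnc2cc1OCCCN1CCCC1` — 230 nM

In a functional assay on NCI-H460 cells (Homo sapiens) for cytotoxicity, read by MTT assay, with a stated time of 72 h (a lower number here means a stronger inhibitor, a higher number a weaker inhibitor), compound 1 stands highest of the three numbers; compound 3 is its nearest neighbour and compound 2 its furthest. The unmeasured compound 4 `COc1cc2c(Oc3ccc(NC(=O)c4nn(-c5ccccc5Br)c(=O)c5ccccc45)cc3F)ccnc2cc1OCCCN1CCCC1` differs from compound 1 by bromo in place of hydrogen on an aromatic carbon.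

Going by the values given here, two measured steps bear on this change, both a halogen entering the same ring. The step of a 2.5-fold lower number from compound 1 to compound 2 (0.40 log units; beyond the scatter) and the step of a 2.1-fold lower number from compound 1 to compound 3 (0.32 log units; beyond the scatter) were each modest and beyond the scatter, and the pair a 1.2-fold higher number from compound 2 to compound 3 (0.08 log units; within the scatter) shows that where the fluoro sits made no difference beyond the scatter. Compound 3 carries its fluoro at the same place where compound 4 carries bromo, so a step of similar size in the same direction is expected, with bromo being a larger atom adding some uncertainty. For compound 4 the expected step is a 1.9-fold lower number from compound 1 to compound 4 (0.28 log units; within the scatter). Compound 4 is therefore estimated at 250 nM in this assay, with a range from 100 nM to 600 nM.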

Compound 4, half-maximal inhibitory concentration: 320 nM
Estimate against measurement, compound 4: 1.3-fold (0.11 log units) below, within the range that was stated.
By their numbers in this assay, from the lowest: compounds 2, 3, 4 and 1 (each within the scatter of the next, the first and the last beyond it).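

In this assay, bromo at this place on the ring gives a 1.5-fold lower number from compound 1 to compound 4 (0.18 log units; within the scatter), so unlike fluoro, which moved the number beyond the scatter at the same carbon, bromo cannot be told apart from the hydrogen of compound 1. Bromo also cannot be told apart from either fluoro compound, with a 1.4-fold higher number from compound 3 to compound 4 (0.14 log units; within the scatter) at the same carbon and a 1.7-fold higher number from compound 2 to compound 4 (0.23 log units; within the scatter) for the pair that differs in both halogen and place, so this halogen sits within the scatter of all its neighbours in the set. Nothing in the data offers an explanation for these steps.

The compounds shown leave open whether chloro, methyl, methoxy or an amine on the same ring carbon would give a step beyond the scatter. They also leave open whether bromo would behave differently at the other ring carbon that carries fluoro in compound 2.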